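Aryl replacement on the thiazole acetic acid series

The source may hold more compounds than are shown below. What is called first, only, known or untested is meant among the compounds shown, and "the series" means these compounds.

Measured compounds:
- compound 1 `N#Cc1cc(-c2nc(C(c3ccc(F)cc3)c3ccc(F)cc3)sc2CC(=O)O)ccc1F`: 520 nM
- compound 2 `Cc1nc(-c2ccc(Cl)cc2)c(CC(=O)O)s1`: 41000 nM
- compound 3 `Nc1nc(-c2ccc(Cl)cc2)c(CC(=O)O)s1`: > 100000 nM (a limit of the assay, not a number)

In an in vitro functional assay on HEK285-7 cells for antagonist activity at prostaglandin D2 receptor 2 (Homo sapiens), read by BRET and beta-arrestin recruitment (on this read-out lower numbers stand for stronger inhibition and higher numbers for weaker inhibition), compound 1 gives 520 nM, the lowest of the two numbers shown. Compound 2 gives 41000 nM, a much higher number. Compound 3 gives > 100000 nM, which is a limit of the assay and not a number. For the measured compounds named here, the one step measured in a single place, an at least 2.4-fold higher number from compound 2 to compound 3 (0.38 log units; beyond the scatter), concerns the position that carries methyl or amino on the shared core, and it ends at the limit of > 100000 nM in this assay, at which 1 of the 3 values shown sits.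

Compound 4 `Cc1cc(-c2nc(C(c3ccc(F)cc3)c3ccc(F)cc3)sc2CC(=O)O)ccn1` differs from compound 1 by 2-methylpyridin-4-yl in place of 3-cyano-4-fluorophenyl on an aromatic carbon. Going by the values given here, no measured step touches this position, so the step carries no direct precedent; the change keeps the number of acceptors and removes the nitrile and fluorine. The step is expected to be small, a 1.5-fold higher number from compound 1 to compound 4 (0.19 log units; within the scatter), with some chance of a modestly higher number. Compound 4 is estimated at 800 nM, within 200 nM to 3000 nM.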

Compound 4, half-maximal inhibitory concentration: 53 nM
The estimate for compound 4 lay 15-fold (1.18 log units) above the measured number; the whole stated range lies above it.
By their numbers in this assay, from the lowest: compound 4; then compound 1; then compound 2. At a limit, above all of these: compound 3.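

In this assay, the aromatic carbon of the shared core that bears the aryl group responds strongly to the identity of that group: 2-methylpyridin-4-yl in place of 3-cyano-4-fluorophenyl gives a 9.8-fold lower number from compound 1 to compound 4 (0.99 log units; beyond the scatter). For the compounds shown here, the only earlier single-place step concerned the position that carries methyl or amino, so this is the first measured change here, and it shows that neither the nitrile nor the fluorine is required and that a ring with a hetero atom is accepted at this position. Nothing measured here bears on the reason for this step.

Still open, as far as these compounds go, is how the step divides among the ring nitrogen, the methyl, and the loss of the nitrile and fluorine. Also open, from the compounds shown here alone, is whether an amine or a methoxy group in place of the methyl on the 2-methylpyridin-4-yl ring would keep the number this low.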